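Moving a Methyl Around the Phenyl Ring

The source may report more compounds than this note shows. Statements on the series, on what has been measured and on what is new or still open speak of the compounds shown alone.

Of the compounds shown here, two have been measured in an assay on CHO cells for displacement of a labelled ligand from adenosine receptor A3 (Homo sapiens), read by scintillation counting, with a stated time of 3 h; a higher number here means a weaker inhibitor, a lower number a stronger inhibitor. Compound 1 `Cn1c(-c2ccc(C(=O)O)cc2)nc2c(NC3CCCC3)ncnc21` gives 25700 nM, and compound 2 `Cc1ccc(-c2nc3c(NC4CCCC4)ncnc3n2C)cc1` gives 480 nM. Compound 2 thus has the lower of the two numbers, and the change of carboxy to methyl on the aromatic carbon produced a 54-fold lower number from compound 1 to compound 2 (1.73 log units; beyond the scatter). Compound 3 `Cc1cccc(-c2nc3c(NC4CCCC4)ncnc3n2C)c1` keeps the same atoms but joins them differently: 3-methylphenyl in place of 4-methylphenyl on an aromatic carbon. Among the compounds with values here, no measured step moves a methyl between positions on this ring, so the known step does not bear directly on this change. For compound 3 the expected step of a 1.5-fold higher number from compound 2 to compound 3 (0.16 log units; within the scatter) is therefore small, within the scatter. Compound 3 is estimated at 700 nM, with a range from 200 nM to 2500 nM.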

Compound 3, inhibition constant: 510 nM
Compound 3: the middle estimate sits 1.4-fold (0.14 log units) above what was measured; the measured number falls inside the stated range.
By their numbers in this assay, from the lowest: compounds 2 and 3 (each within the scatter of the next); then compound 1.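

In this assay, 3-methylphenyl in place of 4-methylphenyl gives a 1.1-fold higher number from compound 2 to compound 3 (0.03 log units; within the scatter) and so stays within the scatter: at these two ring positions, the place of the methyl makes no measurable difference. The earlier step replaced carboxy with methyl and went beyond the scatter, whereas this one keeps the same atoms and only joins them differently. Nothing available explains why these two compounds read alike. From the compounds shown here alone, it remains open whether another group on this phenyl ring, such as an amine or a longer chain, would also read alike at both positions.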